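The source may report more compounds than this note shows. Statements on the series, on what has been measured and on what is new or still open speak of the compounds shown alone.

Measured so far in a functional assay on the whole organism (strain Wister albino) for inhibition, with Rattus norvegicus as the target, read by paw edema, with stated times of 1 h and 3 h, at a dose of 50 mg/kg by the intraperitoneal route; a lower number here means less inhibition, a higher number more inhibition at the dose given (going by the name of the read-out):
compound 1 `CN1C[C@@H](c2ccc(F)cc2)[C@@]2(Cc3ccccc3C2=O)[C@@]12C(=O)Nc1ccccc12` gives 21.1%
compound 2 `CN1C(=O)[C@@]2(c3ccccc31)N(C)C[C@@H](c1ccc(F)cc1)[C@@]21Cc2ccccc2C1=O` gives 26.9%
compound 3 `CN1C[C@@H](c2ccc(Cl)cc2)[C@@]2(Cc3ccccc3C2=O)[C@@]12C(=O)Nc1ccccc12` gives 18.9%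

Compound 4 `CN1C(=O)[C@@]2(c3ccccc31)N(C)C[C@@H](c1ccc(Cl)cc1)[C@@]21Cc2ccccc2C1=O` is not yet measured. Its core and that of compound 2 differ as compound 3 differs from compound 1, by chloro in place of fluoro on an aromatic carbon; both values of that pair lie within the scatter, the step being a number 2.2 percentage points lower from compound 1 to compound 3 (within the scatter). The change from compound 3 to compound 4 is methyl in place of hydrogen on an amide-type nitrogen in a ring, at the same place as the change from compound 1 to compound 2, (methyl in place of hydrogen on an amide-type nitrogen in a ring); that earlier step gave a number 5.8 percentage points higher from compound 1 to compound 2 (within the scatter), within the scatter. Within the data shown here, the same change is therefore expected to give a step of about a number 5.1 percentage points higher from compound 3 to compound 4 (within the scatter) for compound 4, resting on the single earlier step from compound 1 to compound 2. Compound 4 is estimated at 24%, between 14% and 34%.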

Compound 4, a percentage reported as inhibition, in the whole organism at one dose (the size of the read-out at that dose, not a potency): 9.4%
Beside the measured number, compound 4's estimate is 14.6 percentage points above it; measured number outside the range, below it.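

In this assay, methyl in place of hydrogen on the amide-type nitrogen does not carry over between the fluoro and chloro compounds, the new step being a number 9.5 percentage points lower from compound 3 to compound 4 (within the scatter), and the two steps differ: the same change on two cores in this assay, a number 5.8 percentage points higher (within the scatter) from compound 1 to compound 2 and a number 9.5 percentage points lower (within the scatter) from compound 3 to compound 4, 15.3 percentage points apart, beyond the scatter of two such steps. Chloro in place of fluoro does not carry over either, the new step being a number 17.5 percentage points lower from compound 2 to compound 4 (beyond the scatter): the same change on two cores in this assay, a number 2.2 percentage points lower (within the scatter) from compound 1 to compound 3 and a number 17.5 percentage points lower (beyond the scatter) from compound 2 to compound 4, 15.3 percentage points apart, beyond the scatter of two such steps. Both gaps come from the same four compounds, so they show one dependence of the two changes on each other, not two separate findings, and they neither explain it nor establish a rule for the series.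

Open, from the compounds shown here alone, is whether this dependence holds with bromo or methoxy on the aromatic carbon. Also open, going by these compounds, is whether it holds with ethyl or a longer chain on the amide-type nitrogen.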